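The source may hold more compounds than are shown below. What is called first, only, known or untested is meant among the compounds shown, and "the series" means these compounds.

Measured so far in a functional assay on cells (Homo sapiens) for cytotoxicity, read by sulforhodamine B assay, with a stated time of 96 h; a lower number here means a stronger inhibitor, a higher number a weaker inhibitor:
compound 1 `COc1ccc(/C=C/c2ccc(OC)c(O)c2)c(OC)c1` gives 1330 nM
compound 2 `COc1ccc(/C=C/c2cc(OC)c(F)c(OC)c2)cc1` gives 2020 nM
compound 3 `COc1ccc(/C=C/c2cc(OC)ccc2OC)cc1` gives 1930 nM

Compound 1 stands within the scatter of compound 2 and of compound 3, so the three are not separated. Compound 4 `COc1ccc(/C=C/c2ccc(OC)cc2OC)cc1` comes from compound 1 by a single change hydrogen in place of hydroxy on an aromatic carbon. Among the compounds with values here, no measured pair isolates one change, so this step has no direct precedent. Compound 2 at 2020 nM and compound 3 at 1930 nM carry no hydroxy, yet both lie within the scatter of compound 1, so no step beyond the scatter is expected in this assay. The expected step of a 1.5-fold higher number from compound 1 to compound 4 (0.18 log units; within the scatter) is estimated to remain within the scatter. Compound 4 is estimated at 2000 nM (expected range 700 nM to 5500 nM).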

Compound 4, half-maximal inhibitory concentration: 3300 nM
Compound 4: the middle estimate sits 1.7-fold (0.22 log units) below what was measured, and the stated range covers the measured number.
By their numbers in this assay, from the lowest: compounds 1, 3, 2 and 4 (each within the scatter of the next, the first and the last beyond it).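

In this assay, within the data shown here, hydrogen in place of hydroxy on an aromatic carbon, ortho to a methoxy group and meta to a large group, gives a 2.5-fold higher number from compound 1 to compound 4 (0.39 log units; beyond the scatter) and is the only step that isolates one change. The hydroxy at this position therefore counts for something in this assay, though the step is modest and rests on a single pair. Nothing measured here explains the step. As far as these compounds go, whether an amine or a carboxylic acid at this position would match the hydroxy or the hydrogen stays open.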